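The source may hold more compounds than are shown below. What is called first, only, known or untested is meant among the compounds shown, and "the series" means these compounds.

Of the compounds shown here, two sharing one core have so far been measured in an ADME assay on microsomes from liver (Homo sapiens) for metabolic stability; on this read-out lower numbers stand for slow clearance and higher numbers for fast clearance. Compound 1 `COc1cc([C@](O)(CCN(C)C)[C@@H](c2cc3cc(Br)ccc3nc2OC)c2cccc(OC)c2F)cc(OC(C)C)n1` gives 3.4 uL/min in this assay, and compound 2 `COc1cc([C@](O)(CCN(C)C)[C@@H](c2cc3cc(Br)ccc3nc2OC)c2cccc(OC)c2F)cc(OC(F)F)n1` gives 0.1 uL/min. Going by the values given here, the one step known here is a 34-fold lower number from compound 1 to compound 2 (1.53 log units; beyond the scatter), a large move. Among the compounds with values here, compound 2 therefore stands at the lowest of the two numbers, with compound 1 as its only neighbour, far higher.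

Compound 3 `COc1cc([C@](O)(CCN(C)C)[C@@H](c2cc3cc(Br)ccc3nc2OC)c2cccc(OC)c2F)cc(SC)n1` is not yet measured. It differs from compound 2 in a single place: methylsulfanyl in place of difluoromethoxy on an aromatic carbon. Within the data shown here, no measured step concerns this exchange directly. Among the measured compounds shown here, the only step known, a 34-fold lower number from compound 1 to compound 2 (1.53 log units; beyond the scatter), shows that altering the group on this aromatic carbon can shift this assay strongly, so a step beyond the scatter is expected, and since compound 2 already stands lowest, an upward move seems the more likely. Compound 3 is thus estimated to give about 1 uL/min, within 0.1 uL/min to 8 uL/min, meaning an expected step of a 10-fold higher number from compound 2 to compound 3 (1.00 log units; beyond the scatter).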

Compound 3, intrinsic clearance in a liver preparation (reported as CLH), per the amount of preparation that the assay uses: 4.8 uL/min
Beside the measured number, compound 3's estimate is 4.8-fold (0.68 log units) below it; low and high end bracket the measured number.
By their numbers in this assay, from the lowest: compound 2; then compounds 1 and 3 (each within the scatter of the next).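

In this assay, the step to methylsulfanyl, a 48-fold higher number from compound 2 to compound 3 (1.68 log units; beyond the scatter), shows that the low number of compound 2 does not survive this exchange on the aromatic carbon next to the ring nitrogen. Methylsulfanyl and isopropoxy cannot be told apart here, with a 1.4-fold higher number from compound 1 to compound 3 (0.15 log units; within the scatter), which leaves difluoromethoxy as the only one of the three groups whose compound stands apart, although methylsulfanyl has fewer heavy atoms than either of the others. Nothing at hand bears on the reason for this difference.

As far as these compounds go, whether a trifluoromethoxy group, a difluoromethylsulfanyl group or an amine on this carbon would give a number near that of compound 2 stays open. The three compounds also leave open whether these exchanges would read the same with other groups elsewhere on the shared core.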